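Aromatic substituent variation on a shared core

The compounds below may be only part of what the source reports. "The series", "measured", "known", "first", "only" and "open" are said of these compounds alone.

Measured compounds in this series:
compound 1, `C(=C1\CCCN=C1c1cccnc1)\c1ccccc1`: 850 nM
compound 2, `CC(=O)c1ccc(/C=C2\CCCN=C2c2cccnc2)cc1`: 4490 nM
compound 3, `CCCCOc1ccc(/C=C2\CCCN=C2c2cccnc2)cc1`: 1960 nM

All numbers come from an assay on membranes from brain for displacement of a labelled ligand from Neuronal acetylcholine receptor; alpha4/beta2 (Rattus norvegicus), with a stated time of 3 h; a higher number here means a weaker inhibitor, a lower number a stronger inhibitor. Compound 3 stands second highest of the three: the step of a 2.3-fold higher number from compound 1 to compound 3 (0.36 log units; beyond the scatter) separates it from compound 1, and the step of a 2.3-fold lower number from compound 2 to compound 3 (0.36 log units; beyond the scatter) from compound 2. Compound 4, `FC(F)Oc1ccc(/C=C2\CCCN=C2c2cccnc2)cc1`, differs from compound 3 by difluoromethyl in place of butyl on an oxygen on an aromatic ring. Among the measured compounds shown here, no measured step covers this exact change; the steps that bear on it are a 2.3-fold higher number from compound 1 to compound 3 (0.36 log units; beyond the scatter) and a 5.3-fold higher number from compound 1 to compound 2 (0.72 log units; beyond the scatter), both modest rises on adding a group to the aromatic carbon. A smaller group on the oxygen is expected to move the number little, if anything back toward compound 1. For compound 4 the estimate is 1300 nM, within 500 nM to 3500 nM, a step of a 1.5-fold lower number from compound 3 to compound 4 (0.18 log units; within the scatter) expected from compound 3.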

Compound 4, inhibition constant: 1160 nM
Beside the measured number, compound 4's estimate is 1.1-fold (0.05 log units) above it; the range from low to high includes it.
By their numbers in this assay, from the lowest: compounds 1, 4 and 3 (each within the scatter of the next, the first and the last beyond it); then compound 2.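

Difluoromethyl in place of butyl on the oxygen gives (a 1.7-fold lower number from compound 3 to compound 4 (0.23 log units; within the scatter)) in (this assay), so this exchange on the oxygen stays inside the scatter. Difluoromethoxy is the first group on the aromatic carbon that stays level with the unsubstituted compound (a 1.4-fold higher number from compound 1 to compound 4 (0.14 log units; within the scatter)), while replacing acetyl with it gives (a 3.9-fold lower number from compound 2 to compound 4 (0.59 log units; beyond the scatter)). Nothing at hand gives a cause for these steps.

Open, from the compounds shown here alone, is how a longer chain or a benzyl group on the oxygen would read, and how an amine or a carboxylic acid on the aromatic carbon would compare.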